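Chromone acrylamides: benzyl amide to anilide step

The source may hold more compounds than are shown below. What is called first, only, known or untested is meant among the compounds shown, and "the series" means these compounds.

Measured so far:
Compound 1 `COc1ccc2c(=O)c(/C=C/C(=O)NCc3cccc(F)c3)coc2c1`: 10100 nM
Compound 2 `COc1ccc2c(=O)c(/C=C/C(=O)NCc3ccc(C)cc3)coc2c1`: 14300 nM

In a functional assay on Huh-7 cells (Homo sapiens) for inhibition, read by MTT assay, with a stated time of 48 h (a lower number here means a stronger inhibitor, a higher number a weaker inhibitor), compound 2 holds the highest of the two numbers, and its nearest neighbour is compound 1. Among the measured compounds shown here, the only measured step, a 1.4-fold higher number from compound 1 to compound 2 (0.15 log units; within the scatter), changed one aryl group for another on the chain carbon bound to the amide nitrogen and stayed within the scatter. Compound 3 `COc1ccc2c(=O)c(/C=C/C(=O)Nc3ccccc3C)coc2c1` brings a different kind of change: 2-methylphenyl in place of 4-methylbenzyl on an amide-type nitrogen. For the measured compounds named here, no measured step touches this position directly, so the expectation rests on the single step being small, and a change of modest size is expected, a 1.0-fold higher number from compound 2 to compound 3 (0.02 log units; within the scatter). Compound 3 is estimated at 15000 nM (range 5000 nM to 45000 nM).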

Compound 3, half-maximal inhibitory concentration: 26900 nM
Estimate against measurement, compound 3: 1.8-fold (0.25 log units) below; the range from low to high includes it.
By their numbers in this assay, from the lowest: compounds 1, 2 and 3 (each within the scatter of the next, the first and the last beyond it).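

In this assay, among the compounds shown here, the first change to the link between the amide-type nitrogen and the aryl ring gives a 1.9-fold higher number from compound 2 to compound 3 (0.27 log units; within the scatter), so compound 3 does not separate from compound 2. For the compounds shown here, the same replacement set against 3-fluorobenzyl gives a 2.7-fold higher number from compound 1 to compound 3 (0.43 log units; beyond the scatter), the first step beyond the scatter, though only a modest one. No evidence on hand accounts for this result.

Still open, as far as these compounds go, is whether the benzyl-to-aryl change alone carries this step, or the methyl and fluoro groups contribute. Also open, from the compounds shown here alone, is how a longer chain, such as 2-phenylethyl, or an amine on the aryl ring would read at this nitrogen.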